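The source may hold more compounds than are shown below. What is called first, only, known or untested is meant among the compounds shown, and "the series" means these compounds.

The account concerns two compounds already measured and a third still awaiting its number. Compound 1 `C#CC[C@H]1C[C@H](n2cccc2C(C)=O)C(=O)O1` carries the shared core with a short chain ending in an alkyne; in a functional assay on N2a cells (Mus musculus), with a stated time of 48 h, tested at 0.01 uM (a lower number here means a weaker effect, a higher number a stronger effect of the compound at the concentration tested), compound 1 gives 9.04%. Compound 2 `CC(=O)c1cccn1[C@H]1C[C@@H](Cc2cn([C@H]3C[C@H](n4cc(C)c(=O)[nH]c4=O)O[C@@H]3CO)nn2)OC1=O` bears a much larger substituent on the same core; in this assay compound 2 gives 3.67%. That is the lower of the two numbers recorded, yet the gap to compound 1 lies within the scatter of repeated measurements, so the two compounds cannot be told apart on this evidence, and both sit at the weak end of the read-out.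

Compound 3 `CC(=O)c1cccn1[C@H]1C[C@H](Cc2cn([C@H]3C[C@H](n4cc(C)c(=O)[nH]c4=O)O[C@@H]3CO)nn2)OC1=O` is the next to be examined. It differs from compound 2 in a single respect: the two compounds have the same atoms and bonds and differ only in configuration as drawn: 1 of 5 stereo elements differ; a stereocentre at a saturated ring carbon is drawn S in compound 2 and R in compound 3. Going by the values given here, no step between measured compounds of this kind has been recorded, so there is no precedent to lean on. Because compound 2 gives only 3.67% in this assay, little room remains for a further fall. The step expected from a number 1.3 percentage points higher from compound 2 to compound 3 (within the scatter) is therefore small, in no particular direction, and within the scatter. Compound 3 is thus estimated at 5%, with a range from -4% to 14%.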

Compound 3, a percentage reported as activity, at one concentration (the size of the read-out at that concentration, not a potency): 9.52%
Compound 3: middle estimate off by 4.5 percentage points, on the low side; measured number inside the range.
By their numbers in this assay, from the lowest: compounds 2, 1 and 3 (each within the scatter of the next).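

With this pair the account has its first step between measured compounds that differ in one place: in this assay, changing a stereocentre at a saturated ring carbon from S to R gives a number 5.9 percentage points higher from compound 2 to compound 3 (within the scatter). Going by these compounds alone, at the concentration tested, therefore, this configuration does not separate the two compounds, and both remain at the weak end of the read-out, a point on which the earlier compounds, not related by a single change, could say nothing. The comparison is a clean one, with nothing entering or leaving the structure: the fact that compounds 2 and 3 differ only in the configuration as drawn.

The compounds shown leave open whether this stereocentre would matter at another concentration, or in a compound giving a stronger read-out, and whether the other stereo elements would behave in the same way. They also leave open what would follow if the large substituent on the shared core gave way to another group, such as an amine, a carboxylic acid or a longer chain, in either configuration at this stereocentre.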